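The source may report more compounds than this note shows. Statements on the series, on what has been measured and on what is new or still open speak of the compounds shown alone.

Working notes on the series.

Compound 1 `CCCCCCCCC(O)c1ccc2ccc(CC(O)CCCC(=O)O)nc2c1` gives 900 nM in an assay for inhibition of leukotriene B4 receptor 1 (Homo sapiens) (on this read-out lower numbers stand for stronger inhibition and higher numbers for weaker inhibition), the lowest of the three numbers in hand. Compound 2 `CCCCCCCCC(O)c1ccc2ccc(/C=C/CCCC(=O)O)nc2c1` gives 1400 nM in this assay, and a 1.6-fold higher number from compound 1 to compound 2 (0.19 log units; within the scatter) stays within the scatter. For the measured compounds named here, compound 3 `CCCCCCCCC(O)c1ccc2ccc(CCCCCC(=O)O)nc2c1` gives 2800 nM in this assay; a 3.1-fold higher number from compound 1 to compound 3 (0.49 log units; beyond the scatter) is the only step of the three that clears the scatter, while a 2.0-fold higher number from compound 2 to compound 3 (0.30 log units; within the scatter) does not.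

Compound 4 `CCCCCCCCC(O)c1ccc2ccc(CC(O)c3cccc(C(=O)O)c3)nc2c1` is unmeasured. The change from compound 1 is 3-carboxyphenyl in place of 3-carboxypropyl on a saturated chain carbon bound to an oxygen on a saturated carbon and a saturated chain carbon. Going by the values given here, no measured step reproduces this replacement of the chain carrying the acid by an aromatic ring carrying the acid; the steps between compound 1, compound 2 and compound 3 rework the acid-bearing side chain and remove the hydroxy, and they move the numbers by modest amounts at most. Compound 4 keeps the hydroxy whose loss gave a 3.1-fold higher number from compound 1 to compound 3 (0.49 log units; beyond the scatter). On that basis compound 4 is expected to stay close to compound 1, with wide uncertainty, and the estimate for compound 4 in this assay is 1500 nM with a range from 400 nM to 6000 nM. The expected step is a 1.7-fold higher number from compound 1 to compound 4 (0.22 log units; within the scatter), which could fall within the scatter.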

Compound 4, inhibition constant: 10 nM
Compound 4: middle estimate off by 150-fold (2.18 log units), on the high side; the whole stated range lies above it.
By their numbers in this assay, from the lowest: compound 4; then compounds 1, 2 and 3 (each within the scatter of the next, the first and the last beyond it).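

For the compounds shown here, at the saturated chain carbon bound to an oxygen on a saturated carbon and a saturated chain carbon, 3-carboxyphenyl in place of 3-carboxypropyl gives a 90-fold lower number from compound 1 to compound 4 (1.95 log units; beyond the scatter) in this assay and so opens a gap the earlier compounds did not hint at. The largest step among compounds 1, 2 and 3 was only a 3.1-fold higher number from compound 1 to compound 3 (0.49 log units; beyond the scatter) and those changes all kept an open chain carrying the acid, so this position responds far more strongly to a ring-bearing replacement than that earlier set could show. Nothing at hand beyond the binding numbers themselves bears on the origin of this step.

What the compounds shown leave open is how much of the step belongs to the aromatic ring itself and how much to the carboxylic acid it carries, a question that a plain phenyl group or a tetrazole in place of the carboxylic acid would address at this same carbon. Also open, from the compounds shown here alone, is whether the hydroxy on the chain still matters once 3-carboxyphenyl is in place, since its contribution has been read only on the open-chain compounds.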